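The compounds below may be only part of what the source reports. "The series", "measured", "known", "first", "only" and "open" are said of these compounds alone.

Measured so far:
compound 1 `CC(C)C(C)(C)/N=C(\NC#N)Nc1cccnc1` gives 1 mg/kg in a functional assay on the whole organism (blood, strain Wistar-Okamoto) with Rattus norvegicus as the target, with a stated time of 5 days; on this read-out higher numbers stand for an effect only at larger amounts of compound and lower numbers for an effect already at smaller amounts
compound 2 `CCC(C)(CC)/N=C(\NC#N)Nc1cccnc1` gives 0.5 mg/kg in this assay

Among the compounds with values here, compound 2 carries the lowest of the two numbers; its only neighbour is compound 1, and the step of a 2.0-fold lower number from compound 1 to compound 2 (0.30 log units; within the scatter) stays within the scatter. Compound 3 `N#CN/C(=N\c1ccccc1)Nc1cccnc1` is not yet measured. It differs from compound 2 by phenyl in place of 1-ethyl-1-methylpropyl on a double-bonded nitrogen. Within the data shown here, the one measured step swaps one branched alkyl for another and says nothing about an aromatic group entering at this position, so no measured step bears on this change and no direction is indicated. The expected step is a 2.0-fold higher number from compound 2 to compound 3 (0.30 log units; within the scatter). The estimate for compound 3 is 1 mg/kg, with a range from 0.3 mg/kg to 5 mg/kg.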

Compound 3, minimum effective dose: 5 mg/kg
Estimate against measurement, compound 3: 5.0-fold (0.70 log units) below; low and high end bracket the measured number.
By their numbers in this assay, from the lowest: compounds 2 and 1 (each within the scatter of the next); then compound 3.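

In this assay, the group on the double-bonded nitrogen matters: phenyl in place of 1-ethyl-1-methylpropyl brings a 10-fold higher number from compound 2 to compound 3 (1.00 log units; beyond the scatter), and phenyl in place of 1,1,2-trimethylpropyl brings a 5.0-fold higher number from compound 1 to compound 3 (0.70 log units; beyond the scatter). Both steps lie beyond the scatter, unlike the exchange between the two branched alkyl groups, although 1-ethyl-1-methylpropyl and phenyl have the same heavy-atom count. Nothing measured here accounts for this rise.

The compounds shown leave open whether a cyclohexyl group would give a number closer to those of the branched alkyl groups or to that of phenyl. They also leave open how a chlorine atom on the phenyl would change the number.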